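Sulfonyl substituent change in the aortic series

The source may report more compounds than this note shows. Statements on the series, on what has been measured and on what is new or still open speak of the compounds shown alone.

Measured compounds:
compound 1 `CC1(C)Oc2ccc(C(=O)Cc3ccccc3)cc2[C@@H](/N=C(\NC#N)Nc2ccc(Cl)cc2)[C@@H]1O` — in a functional assay (aorta) with Rattus norvegicus as the target (on this read-out lower numbers stand for stronger inhibition and higher numbers for weaker inhibition), compound 1 gives 6800 nM
compound 2 `CC1(C)Oc2ccc(S(=O)(=O)c3ccccc3)cc2[C@@H](/N=C(\NC#N)Nc2ccc(Cl)cc2)[C@@H]1O` — in this assay compound 2 gives 500 nM

For the measured compounds named here, compound 2 holds the lowest of the two numbers in this assay; the only other value is that of compound 1, a step of a 14-fold lower number from compound 1 to compound 2 (1.13 log units; beyond the scatter) away, which came with phenylsulfonyl in place of benzylcarbonyl on an aromatic carbon.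

Compound 3 `CC1(C)Oc2ccc(S(=O)(=O)NC3CCCCC3)cc2[C@@H](/N=C(\NC#N)Nc2ccc(Cl)cc2)[C@@H]1O` keeps the sulfonyl of compound 2 and differs from it by cyclohexylamino in place of phenyl on a sulfonyl sulfur. Going by the values given here, the one measured step, a 14-fold lower number from compound 1 to compound 2 (1.13 log units; beyond the scatter), concerns the same position but a different exchange, a carbonyl-linked group against a sulfonyl-linked one, so it bears only loosely on the present change. Among the compounds with values here, no measured pair compares phenyl with cyclohexylamino on a sulfonyl sulfur. The expectation for this assay is therefore a step of uncertain direction, most likely a modest move upward from compound 2, with a wide range. The estimate for compound 3 is 1200 nM (250 nM to 6000 nM), which would mean an expected step of a 2.4-fold higher number from compound 2 to compound 3 (0.38 log units; beyond the scatter).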

Compound 3, half-maximal inhibitory concentration: 11700 nM
Estimate against measurement, compound 3: 9.8-fold (0.99 log units) below, outside the stated range (above it).
By their numbers in this assay, from the lowest: compound 2; then compounds 1 and 3 (each within the scatter of the next).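

In this assay the exchange of phenyl for cyclohexylamino on a sulfonyl sulfur gives a 23-fold higher number from compound 2 to compound 3 (1.37 log units; beyond the scatter) and so shows that the sulfonyl alone does not secure the low number of compound 2; what sits on the sulfur counts as well. The comparison with the carbonyl-linked group gives a 1.7-fold higher number from compound 1 to compound 3 (0.24 log units; within the scatter) and places cyclohexylsulfamoyl and benzylcarbonyl level in this read-out, so among these three compounds only the phenylsulfonyl of compound 2 stands apart. Nothing available here accounts for the large step from the phenyl to the cyclohexylamino group.

The exchange replaces the six-membered aromatic ring with a non-aromatic one and brings in a nitrogen on the sulfur at the same time, so the compounds shown cannot tell which of these two differences goes with the higher number. A phenylamino group or a cyclohexyl group directly on the sulfonyl sulfur would separate them, and a smaller methylamino group would show whether the ring on the nitrogen matters at all.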